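The compounds below may be only part of what the source reports. "The series", "measured", "known", "first", "only" and "open" are said of these compounds alone.

Of the compounds shown here, three built on one shared scaffold have been tested in a functional assay on MDA-MB-231 cells (Homo sapiens) for cytotoxicity, read by MTT assay, with a stated time of 72 h; a lower number here means a stronger inhibitor, a higher number a weaker inhibitor. Compound 1 `COc1cc2c(Oc3ccc(NC(=O)c4nn(-c5ccc(Br)cc5)c(=O)c5ccccc45)cc3F)ccnc2cc1OCCCN1CCCC1` gives 1160 nM. Compound 2 `COc1cc2c(Oc3ccc(NC(=O)c4nn(-c5ccccc5Br)c(=O)c5ccccc45)cc3F)ccnc2cc1OCCCN1CCCC1` gives 1020 nM. Compound 3 `COc1cc2c(Oc3ccc(NC(=O)c4nn(-c5ccc(Br)cc5)c(=O)c5ccccc45)cc3F)ccnc2cc1OCCCN1CCN(C)CC1` gives 1370 nM. Compound 4 `COc1cc2c(Oc3ccc(NC(=O)c4nn(-c5ccccc5Br)c(=O)c5ccccc45)cc3F)ccnc2cc1OCCCN1CCN(C)CC1` has not yet been tested.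

Compound 2 differs from compound 1 by 2-bromophenyl in place of 4-bromophenyl on an aromatic nitrogen, and this gave a 1.1-fold lower number from compound 1 to compound 2 (0.06 log units; within the scatter). Compound 3 differs from compound 1 by 4-methylpiperazin-1-yl in place of pyrrolidin-1-yl on a saturated chain carbon, three bonds along the chain from an oxygen on an aromatic ring, which gave a 1.2-fold higher number from compound 1 to compound 3 (0.07 log units; within the scatter). Both shifts are small enough to lie inside the usual scatter of repeated measurements, so the three compounds cannot be ranked against each other.

Compound 4 differs from compound 3 by 2-bromophenyl in place of 4-bromophenyl on an aromatic nitrogen. This is the same change already made from compound 1 to compound 2, at the same place on the core, and the two cores differ only by 4-methylpiperazin-1-yl in place of pyrrolidin-1-yl on a saturated chain carbon, three bonds along the chain from an oxygen on an aromatic ring. Because that earlier step was a 1.1-fold lower number from compound 1 to compound 2 (0.06 log units; within the scatter), the step from compound 3 to compound 4 is expected to be about as small, around a 1.1-fold lower number from compound 3 to compound 4 (0.04 log units; within the scatter). Compound 4 is therefore estimated to give 1250 nM, with a plausible span from 700 nM to 2300 nM.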

Compound 4, half-maximal inhibitory concentration: 1680 nM
For compound 4 the middle estimate is 1.3-fold (0.13 log units) below the measured one; measured number inside the range.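

Putting 2-bromophenyl in place of 4-bromophenyl on the core of compound 3 gave a 1.2-fold higher number from compound 3 to compound 4 (0.09 log units; within the scatter) in this assay, and this step agrees with the same change on the core of compound 1: the same change on two cores in this assay, a 1.1-fold lower number (0.06 log units; within the scatter) from compound 1 to compound 2 and a 1.2-fold higher number (0.09 log units; within the scatter) from compound 3 to compound 4, 1.4-fold (0.14 log units) apart, within the scatter of two such steps. Putting 4-methylpiperazin-1-yl in place of pyrrolidin-1-yl, this time on the core of compound 2, gave a 1.6-fold higher number from compound 2 to compound 4 (0.22 log units; within the scatter), and this step also agrees with its earlier counterpart: the same change on two cores in this assay, a 1.2-fold higher number (0.07 log units; within the scatter) from compound 1 to compound 3 and a 1.6-fold higher number (0.22 log units; within the scatter) from compound 2 to compound 4, 1.4-fold (0.14 log units) apart, within the scatter of two such steps. So neither change shows a measurable effect on either core, but with every step this small, the series does not show that a real effect of fixed size or direction carries from one core to the other.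

Still open, as far as these compounds go, is whether a plain phenyl or a chlorophenyl on the aromatic nitrogen would separate from the bromophenyl compounds. The same question stands for a morpholine or a dimethylamine at the end of the chain, or for a longer chain.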